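Amide aryl substituent change in the dopamine receptor series

A few compounds are considered here, and "the series" means these few. Any claim that something is new, unique, unknown or untested is made for them only; others in the source may bear on it.

Measured so far:
Compound 1, `CCCN(CC[C@H]1CC[C@H](NC(=O)/C=C/c2cccc(Cl)c2)CC1)[C@H]1CCc2nc(N)sc2C1`, gives 1.2 nM in an assay on brain for displacement of a labelled ligand from D(3) dopamine receptor (Rattus norvegicus); on this read-out higher numbers stand for weaker inhibition and lower numbers for stronger inhibition.
Compound 2, `CCCN(CC[C@H]1CC[C@H](NC(=O)c2ccc(-n3cccn3)cc2)CC1)[C@H]1CCc2nc(N)sc2C1`, gives 3 nM in this assay.

Among the compounds with values here, compound 2 stands at the highest of the two numbers; the only measured step, a 2.5-fold higher number from compound 1 to compound 2 (0.40 log units; beyond the scatter), is modest and concerns the group on the carbonyl carbon. Compound 3, `CCCN(CC[C@H]1CC[C@H](NC(=O)c2ccc(-c3noc(C(C)C)n3)cc2)CC1)[C@H]1CCc2nc(N)sc2C1`, differs from compound 2 by 5-isopropyl-1,2,4-oxadiazol-3-yl in place of 1H-pyrazol-1-yl on an aromatic carbon. Within the data shown here, no measured step covers this exchange, so the expectation rests on the modest size of a 2.5-fold higher number from compound 1 to compound 2 (0.40 log units; beyond the scatter) alone. Compound 3 is expected to show a small step, a 1.3-fold higher number from compound 2 to compound 3 (0.12 log units; within the scatter), toward a somewhat higher number, within or near the scatter. Compound 3 is estimated at 4 nM, range 1.5 nM to 12 nM.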

Compound 3, inhibition constant: 2 nM
Beside the measured number, compound 3's estimate is 2.0-fold (0.30 log units) above it; measured number inside the range.
By their numbers in this assay, from the lowest: compounds 1, 3 and 2 (each within the scatter of the next, the first and the last beyond it).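

At the aromatic carbon para to a large group, 5-isopropyl-1,2,4-oxadiazol-3-yl can replace 1H-pyrazol-1-yl in this assay without a step beyond the scatter (a 1.5-fold lower number from compound 2 to compound 3 (0.18 log units; within the scatter)). This place therefore accepts a five-membered aromatic ring with 3 hetero atoms and an added isopropyl group as well as the pyrazole. No measured property bears on this result.

From the compounds shown here alone, whether a carboxylic acid or an aminomethyl group at this place would give a similar number remains open. So does the effect of a longer chain, such as hexyl, in place of the isopropyl group.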